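The source may report more compounds than this note shows. Statements on the series, on what has been measured and on what is new or still open speak of the compounds shown alone.

Measured compounds in an ADME assay on MT4 cells (Homo sapiens) for cytotoxicity, read by MTT assay; a higher number here means that more compound is tolerated, a lower number that less compound is tolerated:
Compound 1 `Cc1cc(C)cc(S(=O)(=O)c2c(C(=O)NC(c3ccc(Cl)cc3)C3CC3)[nH]c3ccc(Cl)cc23)c1` gives > 47300 nM, which is a limit of the assay and not a number.
Compound 2 `Cc1cc(C)cc(S(=O)(=O)c2c(C(=O)NC(C)c3cc(F)cc(F)c3)[nH]c3ccc(Cl)cc23)c1` gives > 49700 nM, again a limit of the assay.
Compound 3 `Cc1cc(C)cc(S(=O)(=O)c2c(C(=O)NC(C)c3ccco3)[nH]c3ccc(Cl)cc23)c1` gives > 54700 nM, again a limit of the assay.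

Compound 1 thus stands at a limit only, and the two further values shown are limits as well, so none of the three compounds can be ordered against another. Compound 4 `Cc1cc(C)cc(S(=O)(=O)c2c(C(=O)NCC(=O)NCc3ccccc3F)[nH]c3ccc(Cl)cc23)c1` differs from compound 1 by a group of 12 heavy atoms (9 carbon, 1 nitrogen, 1 oxygen, 1 fluorine; one six-membered aromatic ring of carbon only) in place of a group of 11 heavy atoms (10 carbon, 1 chlorine; one three-membered non-aromatic ring of carbon only, one six-membered aromatic ring of carbon only), on an amide-type nitrogen. The measured steps that bear on this change are the two that likewise replace the group on the amide-type nitrogen of compound 1: a step that the two limits leave unreadable from compound 1 to compound 2 and a step that the two limits leave unreadable from compound 1 to compound 3. Neither has a readable size, since each ends at a limit, as the limit of > 47300 nM in this assay, at which 1 of the 3 values shown sits, the limit of > 49700 nM in this assay, at which 1 of the 3 values shown sits, and the limit of > 54700 nM in this assay, at which 1 of the 3 values shown sits, show. For compound 4 no step beyond the scatter is therefore expected in this assay in either direction, the expected step being a step that the limit leaves unreadable from compound 1 to compound 4, and the read-out is expected to come back as a limit once more. Compound 4 is estimated at 50000 nM, with a range from 25000 nM to 100000 nM.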

Compound 4, half-maximal cytotoxic concentration: > 47300 nM
Compound 4: no number, only a limit; the forecaster's own chance of this, stated with the estimate: 85%; the middle value is on the limit's open side.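

In this assay, among these compounds, compound 4 gives > 47300 nM, a limit of the assay and not a number, so no step between compound 4 and compound 1, compound 2 or compound 3 can be read. The compounds shown leave open at what concentration any of the four becomes cytotoxic, and whether the group on the amide-type nitrogen alters that concentration.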